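Lengthening a side chain with a fluorophenyl group

The source may report more compounds than this note shows. Statements on the series, on what has been measured and on what is new or still open speak of the compounds shown alone.

Compound 1 `C=CCOc1cc(/C=C\c2cc(OC)c(OC)c(OC)c2)ccc1OC` carries a short vinyl group on the saturated chain carbon bound to an oxygen on an aromatic ring of the shared core. Within the data shown here, in a functional assay on MCF7 cells (Homo sapiens) for inhibition, read by MTT assay, with a stated time of 3 days (on this read-out lower numbers stand for stronger inhibition and higher numbers for weaker inhibition), compound 1 gives 12000 nM, the second highest of the three numbers known so far. Compound 2 `COc1ccccc1/C=C/CCCOc1cc(/C=C\c2cc(OC)c(OC)c(OC)c2)ccc1OC` gives 21000 nM, and compound 3 `COCOc1ccccc1/C=C/CCCOc1cc(/C=C\c2cc(OC)c(OC)c(OC)c2)ccc1OC` gives 4400 nM.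

Compound 4 `COc1ccc(/C=C\c2cc(OC)c(OC)c(OC)c2)cc1OCCC/C=C/c1ccc(F)cc1` has not yet been measured. It differs from compound 1 in one place: 4-(4-fluorophenyl)but-3-en-1-yl in place of vinyl on a saturated chain carbon bound to an oxygen on an aromatic ring.

The closest guide is the step from compound 1 to compound 2, in which a 4-(2-methoxyphenyl)but-3-en-1-yl group replaced the same vinyl group: a 1.8-fold higher number from compound 1 to compound 2 (0.24 log units; within the scatter). The step from compound 2 to compound 3, a 4.8-fold lower number from compound 2 to compound 3 (0.68 log units; beyond the scatter), changed the group on that chain in another way, methoxy in place of hydrogen, and bears only indirectly on the fluorophenyl case. Because a 1.8-fold higher number from compound 1 to compound 2 (0.24 log units; within the scatter) stayed within the scatter, a comparable long aryl-bearing chain in compound 4 is expected to leave the number close to where compound 1 stands.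

The expected step from compound 1 to compound 4 is a 1.3-fold higher number from compound 1 to compound 4 (0.10 log units; within the scatter), which amounts to no change beyond the scatter. Compound 4 is therefore estimated at 15000 nM, with a likely range from 5000 nM to 45000 nM.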

Compound 4, half-maximal inhibitory concentration: 16000 nM
Compound 4: the middle estimate sits 1.1-fold (0.03 log units) below what was measured; low and high end bracket the measured number.
By their numbers in this assay, from the lowest: compound 3; then compounds 1, 4 and 2 (each within the scatter of the next).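

In this assay, exchanging vinyl for 4-(4-fluorophenyl)but-3-en-1-yl on the saturated chain carbon bound to an oxygen on an aromatic ring gives a 1.3-fold higher number from compound 1 to compound 4 (0.12 log units; within the scatter), so a second long chain ending in an aromatic ring, with 11 heavy atoms in place of 2, also leaves the number within the scatter. Changing only the ring at the end of the chain shows that compound 3 stands apart from both other long-chain compounds: 4-fluorophenyl in place of 2-methoxyphenyl gives a 1.3-fold lower number from compound 2 to compound 4 (0.12 log units; within the scatter), whereas 4-fluorophenyl in place of 2-(methoxymethoxy)phenyl gives a 3.6-fold higher number from compound 3 to compound 4 (0.56 log units; beyond the scatter). Nothing available here offers an explanation for these numbers.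

Among the long-chain compounds, only the 2-(methoxymethoxy)phenyl group gives a number that differs beyond the scatter, so it remains open whether other groups on that end ring could lower the number further. As far as these compounds go, how an end ring carrying an amine or a carboxylic acid, or a longer chain in place of but-3-en-1-yl, would read in this assay also remains open.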